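Three compounds at the assay limit, and a fourth

The source may report more compounds than this note shows. Statements on the series, on what has been measured and on what is new or still open speak of the compounds shown alone.

Compound 1 `CCCC/C=C\CCCCCCCCCc1cc(=O)c2c(O)c(C)c(O)c(C)c2o1` is measured in a functional assay on MDA-MB-231 cells (Homo sapiens) for antiproliferative activity, read by MTT assay (a lower number here means a stronger inhibitor, a higher number a weaker inhibitor), and gives > 87000 nM, which is a limit of the assay.
Compound 2 `CCCCC/C=C\C/C=C\CCCCCCCc1cc(=O)c2c(O)c(C)c(OCOC)cc2o1` gives > 87000 nM in this assay, again a limit.
Compound 3 `CCCC/C=C\CCCCCCCCCc1cc(=O)c2c(O)c(C)c(OCOC)c(C)c2o1` gives > 87000 nM in this assay, also a limit.

Compound 3 and compound 1 differ by a single change, (hydrogen in place of methoxymethyl on an oxygen on an aromatic ring), and because every value sits at the limit of > 87000 nM in this assay, at which 3 of the 3 values shown sit, the step that the two limits leave unreadable from compound 3 to compound 1 cannot be read. Compound 4 `CCCCC/C=C\C/C=C\CCCCCCCc1cc(=O)c2c(O)c(C)c(O)cc2o1` is still to be measured in this assay. It arises from compound 2 by the same change, (hydrogen in place of methoxymethyl on an oxygen on an aromatic ring); the difference between the core of compound 2 and the core of compound 3 is not broken down here. Compound 4 is expected to remain at the limit, so the step that the limit leaves unreadable from compound 2 to compound 4 is expected to be unreadable as well. This expectation rests on compound 2, whose value > 87000 nM is a limit, and on (the limit of > 87000 nM in this assay, at which 3 of the 3 values shown sit). The estimate for compound 4 is 100000 nM, between 40000 nM and 300000 nM.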

Compound 4, half-maximal inhibitory concentration: 16100 nM
Beside the measured number, compound 4's estimate is 6.2-fold (0.79 log units) above it, and the stated range ends above it.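

In this assay, putting hydrogen in place of methoxymethyl gives an at least 5.4-fold lower number from compound 2 to compound 4 (0.73 log units; beyond the scatter), and the real step may be larger, as the starting point is only a limit: the limit of > 87000 nM in this assay, at which 3 of the 4 values shown sit.
On the other core, the same change, from compound 3 to compound 1, cannot be read, as neither compound gives a value beyond the limit. So the gain is seen on one core only: it is neither confirmed nor ruled out on the other, and the two cores differ in more than this one change.

Still open, from the compounds shown here alone, is how an amine in place of the hydroxy would read in this assay. Also open, going by these compounds, is whether a shorter chain on the core of compound 4 would keep its activity.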